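A few compounds are considered here, and "the series" means these few. Any claim that something is new, unique, unknown or untested is made for them only; others in the source may bear on it.

Measured so far:
Compound 1 `O=C(Nc1cccc(-n2cc(-c3ccncc3)c(-c3ccc(Cl)c(O)c3)n2)c1)Nc1cccc(C(F)(F)F)c1` gives > 32500 nM in a functional assay on HOP-62 cells (Homo sapiens) for inhibition, read by sulforhodamine B assay, with a stated time of 48 h; on this read-out higher numbers stand for weaker inhibition of growth and lower numbers for stronger inhibition of growth; this is a limit of the assay, not a number.
Compound 2 `COc1cc(-c2nn(-c3cccc(NC(=O)Nc4cc(C(F)(F)F)cc(C(F)(F)F)c4)c3)cc2-c2ccncc2)ccc1Cl` gives 1590 nM in this assay.

Compound 2 is thus the only one of the two with a measured number in this assay; the other value is a limit (the limit of > 32500 nM in this assay, at which 1 of the 2 values shown sits). Compound 3 `O=C(Nc1cccc(-n2cc(-c3ccncc3)c(-c3ccc(Cl)c(O)c3)n2)c1)Nc1cc(C(F)(F)F)cc(C(F)(F)F)c1` has not yet been measured. It differs from compound 2 by hydrogen in place of methyl on an oxygen on an aromatic ring. Going by the values given here, no pair of measured compounds differs in just one place, so no measured step shows what this change does. Compound 1, which also carries the hydroxy group, sits at a limit in this assay, while compound 3 shares that group but otherwise matches compound 2. On that basis, the change from compound 2 to compound 3 is expected to weaken growth inhibition by a 5.0-fold higher number from compound 2 to compound 3 (0.70 log units; beyond the scatter), a step beyond the usual scatter. Compound 3 is therefore estimated at 8000 nM in this assay, with a likely range from 2000 nM to 32500 nM, and a real chance that only a limit is reported.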

Compound 3, concentration for total growth inhibition: 1980 nM
For compound 3 the middle estimate is 4.0-fold (0.61 log units) above the measured one; measured number outside the range, below it.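

Methoxy to hydroxy on the 4-chloro-3-methoxyphenyl ring now has a measured step: in this assay it gives a 1.2-fold higher number from compound 2 to compound 3 (0.10 log units; within the scatter), so with two trifluoromethyl groups on the other ring, growth inhibition does not depend measurably on the methyl on that oxygen. With the hydroxy group held fixed, trifluoromethyl in place of hydrogen on an aromatic carbon gives an at least 16-fold lower number from compound 1 to compound 3 (1.21 log units; beyond the scatter), and of these two changes only this one lies beyond the scatter. The value of compound 1 is a limit, not a number: the limit of > 32500 nM in this assay, at which 1 of the 3 values shown sits.

Whether methoxy and hydroxy also match when that added trifluoromethyl is absent remains open, as the compounds shown offer no such pair. Also open, on these data alone, is what a longer ether such as ethoxy, or an amine, would do in place of the hydroxy group.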